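Cyclohexyl for isobutylpiperazinyl on an acid ceramidase inhibitor core

The source may hold more compounds than are shown below. What is called first, only, known or untested is meant among the compounds shown, and "the series" means these compounds.

Three compounds share a urea-linked phenylbutyl chain. Compound 1 `CN1CCc2oc(=O)n(C(=O)NCCCCc3ccccc3)c2C1` gives 516 nM in an assay on HEK293 cells for inhibition of acid ceramidase (Homo sapiens), read by fluorescence, with stated times of 10 min and 3 h; on this read-out higher numbers stand for weaker inhibition and lower numbers for stronger inhibition. Compound 3 `O=C(NCCCCc1ccccc1)n1c2c(oc1=O)CCN(Cc1ccccc1)C2` gives 436 nM, and the step of a 1.2-fold lower number from compound 1 to compound 3 (0.07 log units; within the scatter) concerns only the amine substituent. Compound 2 `CC(C)CN1CCN(c2ccc3c(c2)oc(=O)n3C(=O)NCCCCc2ccccc2)CC1` gives 127 nM, the lowest of the three numbers, with both other compounds beyond the scatter above it.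

Compound 4 `O=C(NCCCCc1ccccc1)n1c(=O)oc2cc(C3CCCCC3)ccc21` differs from compound 2 by cyclohexyl in place of 4-isobutylpiperazin-1-yl on an aromatic carbon. Within the data shown here, no measured step touches this position, and the one measured step is small and elsewhere. Compounds 1 and 3, which carry a different core, show higher numbers than compound 2, but no direct comparison exists. A moderate rise is therefore expected, a 2.0-fold higher number from compound 2 to compound 4 (0.29 log units; within the scatter), with wide uncertainty. Compound 4 is estimated at 250 nM, ranging from 80 nM to 800 nM.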

Compound 4, half-maximal inhibitory concentration: 89 nM
Estimate against measurement, compound 4: 2.8-fold (0.45 log units) above; low and high end bracket the measured number.
By their numbers in this assay, from the lowest: compounds 4 and 2 (each within the scatter of the next); then compounds 3 and 1 (each within the scatter of the next).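

Exchanging 4-isobutylpiperazin-1-yl for cyclohexyl on this aromatic carbon gives a 1.4-fold lower number from compound 2 to compound 4 (0.15 log units; within the scatter) in this assay, so the two groups cannot be told apart here. The number therefore holds with a carbon-only ring in place of the ring with 2 hetero atoms, so neither the piperazine nitrogens nor the isobutyl group is needed at this position. Nothing available explains this tolerance.

From the compounds shown here alone, whether a smaller group such as methyl or a flat phenyl ring would hold the number at this carbon remains open. So does the effect of a carboxylic acid or a primary amine there.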